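This account rests on a few compounds, and the source may have more. Where it says the series, first, only, none or still open, it means among the compounds named here.

On these data alone, compound 1 `CC(=O)N1c2ccccc2CCC1C(=O)Nc1cc(C(F)(F)F)cc(C(F)(F)F)c1` was tested in a functional assay on ACHN cells (Homo sapiens) for cytotoxicity, read by sulforhodamine B assay, with a stated time of 72 h (on this read-out lower numbers stand for stronger inhibition of growth and higher numbers for weaker inhibition of growth), and came back only as a limit of the assay, > 70000 nM, so its exact potency is unknown. Compound 2 `O=C(Nc1ccccc1O)C1CCc2ccccc2N1C(=O)c1ccccc1` shares the same core and in this assay compound 2 gives 4260 nM. Within the data shown here, the two measured results are not joined by a single-point change, and the one fact about compound 1 is the limit itself, (the limit of > 70000 nM in this assay, at which 1 of the 2 values shown sits).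

Compound 3 `O=C(Nc1cc(C(F)(F)F)cc(C(F)(F)F)c1)C1CCc2ccccc2N1C(=O)c1cccc(Cl)c1` is built from compound 1 by one change on a carbonyl carbon: 3-chlorophenyl in place of methyl on a carbonyl carbon. Among the measured compounds shown here, no measured pair isolates this change, so the expected step from compound 1 to compound 3 is an at least 14-fold lower number from compound 1 to compound 3 (1.14 log units; beyond the scatter), a clear gain in growth inhibition, beyond the scatter, because compound 2 gives 4260 nM and carries the aromatic carbonyl on the ring nitrogen that compound 3 also has. On that basis compound 3 is estimated at 5000 nM, within a range from 1000 nM to 40000 nM.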

Compound 3, concentration for 50% growth inhibition: 813 nM
Compound 3: middle estimate off by 6.2-fold (0.79 log units), on the high side, outside the stated range (below it).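

Among these compounds, compound 1 and compound 3 differ in one place only, so this pair gives the first direct reading of the group on this carbonyl carbon. In this assay, exchanging acetyl for (3-chlorophenyl)carbonyl gives an at least 86-fold lower number from compound 1 to compound 3 (1.93 log units; beyond the scatter) and shows that growth inhibition depends strongly on what sits at this position. The step is a minimum and not an exact size, because the value for compound 1 is only a limit: the limit of > 70000 nM in this assay, at which 1 of the 3 values shown sits.

The pair does not separate the contribution of the six-membered aromatic ring from that of its chlorine, and a plain phenyl in the same place would draw that line. On these data alone, how an alkyl chain longer than methyl, an amine or a carboxylic acid would behave on this carbonyl carbon also remains open.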